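Pyrimidine-fused series, single-concentration kinase inhibition: compound 3

The source may report more compounds than this note shows. Statements on the series, on what has been measured and on what is new or still open speak of the compounds shown alone.

Measured so far:
- compound 1 `Cc1cc2nc(N)nc(N)c2c(=O)[nH]1`: 5%
- compound 2 `Cc1cc2nc(-c3ccccc3)nc(N)c2c(=O)[nH]1`: 7%

In an assay on isolated protein for inhibition of RAC-alpha serine/threonine-protein kinase (Homo sapiens), read by mobility shift assay, tested at 30 uM (a lower number here means less inhibition, a higher number more inhibition at the concentration tested (going by the name of the read-out)), compound 2 gives 7% and is the highest of the two numbers, though its nearest neighbour compound 1 at 5% sits a number 2 percentage points higher from compound 1 to compound 2 (within the scatter), so the two compounds are not separated. Both numbers are low, so neither compound shows appreciable inhibition at the concentration tested.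

The next compound, compound 3 `Cc1nc(N)c2c(=O)[nH]c(C)cc2n1`, differs from compound 2 in one place: methyl in place of phenyl on an aromatic carbon.

Going by the values given here, only one measured step bears on this position: a number 2 percentage points higher from compound 1 to compound 2 (within the scatter), where phenyl replaced amino on the same aromatic carbon and the number did not move beyond the scatter. Nothing in the series shows this position moving the read-out in this assay, so the expectation is that swapping phenyl for methyl will give a step of a number 1 percentage points lower from compound 2 to compound 3 (within the scatter), none beyond the scatter. Compound 3 is therefore estimated at 6%, with a range from -5% to 17%.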

Compound 3, a percentage reported as inhibition, at one concentration (the size of the read-out at that concentration, not a potency): -2%
Beside the measured number, compound 3's estimate is 8 percentage points above it, within the range that was stated.
By their numbers in this assay, from the lowest: compounds 3, 1 and 2 (each within the scatter of the next).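

In this assay the aromatic carbon between two ring nitrogen atoms has now carried amino, phenyl and methyl, and both new steps, a number 9 percentage points lower from compound 2 to compound 3 (within the scatter) and a number 7 percentage points lower from compound 1 to compound 3 (within the scatter), stay within the scatter. Going by these compounds alone, exchanging the phenyl ring for the single carbon of methyl therefore does not separate the compounds, and neither does exchanging amino for methyl, which goes beyond the one earlier step by covering a third group that is small and carries no ring. No measurement available here accounts for the absence of a separation at this position.

As far as these compounds go, what a carboxylic acid, a longer alkyl chain or a substituted amine would do on this carbon stays open. Also open, from the compounds shown here alone, is whether this position can raise inhibition at all from a shared core that shows little at the concentration tested.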